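Replacing trifluoromethyl with fluoro on the aromatic ring

A few compounds are considered here, and "the series" means these few. Any claim that something is new, unique, unknown or untested is made for them only; others in the source may bear on it.

Measured in a functional assay on U-937 cells (Homo sapiens) for antiproliferative activity, read by MTT assay, with a stated time of 72 h; on this read-out lower numbers stand for stronger inhibition and higher numbers for weaker inhibition:
Compound 1 `O=C(CCCCCCc1nc(-c2ccccc2)no1)C(F)(F)F`: 410 nM
Compound 2 `O=C(CCCCCCc1nc(-c2ccc(C(F)(F)F)cc2)no1)C(F)(F)F`: 1960 nM

Of these two compounds, compound 2 has the higher number, 1960 nM, and so the weaker inhibition. Within the data shown here, its only neighbour is compound 1, at 410 nM. The next compound, compound 3 `O=C(CCCCCCc1nc(-c2ccc(F)cc2)no1)C(F)(F)F`, is changed on the aromatic ring: fluoro in place of trifluoromethyl on an aromatic carbon. In words, this is fluoro in place of trifluoromethyl on an aromatic carbon.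

Among the measured compounds shown here, one measured step bears on this change: a 4.8-fold higher number from compound 1 to compound 2 (0.68 log units; beyond the scatter). That step put trifluoromethyl in place of hydrogen on an aromatic carbon, and it is modest but beyond the scatter. For the measured compounds named here, no fluoro compound has yet been measured in this assay, so this single step is only a rough guide. Taking trifluoromethyl away again is expected to reverse most of that rise, though not necessarily all of it. The estimated step is a 3.2-fold lower number from compound 2 to compound 3 (0.50 log units; beyond the scatter), towards a lower number. The expected value for compound 3 is 620 nM, within an estimated range from 280 nM to 1400 nM.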

Compound 3, half-maximal inhibitory concentration: 2350 nM
Compound 3: middle estimate off by 3.8-fold (0.58 log units), on the low side, outside the stated range (above it).
By their numbers in this assay, from the lowest: compound 1; then compounds 2 and 3 (each within the scatter of the next).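

In this assay the exchange of trifluoromethyl for fluoro gives a 1.2-fold higher number from compound 2 to compound 3 (0.08 log units; within the scatter) and so does not bring back the lower number of compound 1, with hydrogen at this position; compound 2 and compound 3 cannot be told apart. Fluoro in place of hydrogen gives a 5.7-fold higher number from compound 1 to compound 3 (0.76 log units; beyond the scatter) and, like the earlier trifluoromethyl step, lies beyond the scatter, so the rise is not confined to trifluoromethyl and compound 1 stays the strongest of the three. Nothing measured here explains why these two different groups on an aromatic carbon give numbers within the scatter of each other, or why either differs from hydrogen.

On these data alone, it remains open whether any other group at this position, such as methoxy, an amine or a carboxylic acid, would match hydrogen or would also give a higher number in this read-out. As far as these compounds go, it also remains open whether a longer chain in the shared core would alter the gap between the hydrogen compound and its two halogen-bearing relatives.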